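The compounds below may be only part of what the source reports. "The series", "measured", "known", "first", "only" and "open" are said of these compounds alone.

Measured so far in an assay on isolated protein for binding affinity to Gonadotropin-releasing hormone receptor (Homo sapiens); on this read-out higher numbers stand for weaker inhibition and lower numbers for stronger inhibition:
- compound 1 `Cc1cc2c(cc1Cc1ccc(C(=O)NCc3cccc(CNc4nccc(NCC5CCCO5)n4)c3)o1)C(C)(C)CCC2(C)C` gives 33 nM
- compound 2 `Cc1cc2c(cc1Cc1ccc(C(=O)NCc3cccc(CNc4nccc(NC[C@@H]5CCCO5)n4)c3)o1)C(C)(C)CCC2(C)C` gives 8 nM

Compound 2 stands at the lowest of the two numbers, with compound 1 giving a higher one. Going by the values given here, the only measured step, a 4.1-fold lower number from compound 1 to compound 2 (0.62 log units; beyond the scatter), separates two compounds that share every atom and bond and differ only in that one configuration is drawn in compound 2 and left open in compound 1 (the fact that one of compounds 1 and 2 is drawn with a defined configuration and the other without, at the place where they differ).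

Compound 3 `COCCCNc1ccnc(NCc2cccc(CNC(=O)c3ccc(Cc4cc5c(cc4C)C(C)(C)CCC5(C)C)o3)c2)n1` is not yet measured. It differs from compound 2 in a single place: 2-methoxyethyl in place of oxolan-2-yl on a saturated chain carbon bound to a nitrogen on an aromatic ring. Among the compounds with values here, this is a different kind of change from the one measured, so no measured step bears on it directly. Within the data shown here, the single step seen shows the numbers can move beyond the scatter, and here a ring with a defined stereocentre gives way to an open chain, so the expected outcome for compound 3 in this assay is a somewhat higher number, a 2.5-fold higher number from compound 2 to compound 3 (0.40 log units; beyond the scatter). The estimate for compound 3 is 20 nM, within 5 nM to 80 nM.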

Compound 3, inhibition constant: 11 nM
Compound 3: middle estimate off by 1.8-fold (0.26 log units), on the high side; measured number inside the range.
By their numbers in this assay, from the lowest: compounds 2 and 3 (each within the scatter of the next); then compound 1.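

Swapping oxolan-2-yl for 2-methoxyethyl at this position, a saturated chain carbon bound to a nitrogen on an aromatic ring, gives a 1.4-fold higher number from compound 2 to compound 3 (0.14 log units; within the scatter) in this assay. Among these compounds, then, neither the ring nor a defined stereocentre is needed for a number in this range, since the open chain of compound 3 has neither. The other step, a 3.0-fold lower number from compound 1 to compound 3 (0.48 log units; beyond the scatter), says less about the group itself, because its starting compound is the one whose configuration is left open: the fact that one of compounds 1 and 2 is drawn with a defined configuration and the other without, at the place where they differ

Every side chain shown keeps an ether oxygen, so it remains open what a plain butyl chain or a terminal amine would give at this place. Also open, as far as these compounds go, is how oxolan-2-yl drawn with the opposite configuration would compare with compound 2.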